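A few compounds are considered here, and "the series" means these few. Any claim that something is new, unique, unknown or untested is made for them only; others in the source may bear on it.

Compound 1 `COc1ccc(-c2nc(CNc3ccc(C(=O)NO)cc3)n(-c3ccccc3)n2)cc1` gives 163 nM in an assay on Sf9 cells for inhibition of protein deacetylase HDAC6 (Homo sapiens), read by fluorescence, with a stated time of 40 min; on this read-out lower numbers stand for stronger inhibition and higher numbers for weaker inhibition.
Compound 2 `O=C(NO)c1ccc(NCc2nc(-c3ccccc3)nn2-c2ccc(F)cc2)cc1` gives 274 nM in this assay.
Compound 3 `Cc1cccc(-n2nc(-c3ccccc3)nc2CNc2ccc(C(=O)NO)cc2)c1` gives 388 nM in this assay.

Among these three numbers compound 1 stands lowest; its gap to compound 2 lies within the scatter, while its gap to compound 3 lies beyond it. Compound 4 `Cc1cccc(-c2nc(CNc3ccc(C(=O)NO)cc3)n(-c3ccccc3)n2)c1` differs from compound 1 in one place: 3-methylphenyl in place of 4-methoxyphenyl on an aromatic carbon. Among the measured compounds shown here, no measured step changes the group on that aromatic carbon. For the measured compounds named here, the only single-point step seen, a 1.4-fold higher number from compound 2 to compound 3 (0.15 log units; within the scatter), brings in 3-methylphenyl on an aromatic nitrogen and stays within the scatter. Because a 1.4-fold higher number from compound 2 to compound 3 (0.15 log units; within the scatter) is small, only a small shift in this assay is expected for compound 4, with no clear direction beyond the scatter. For compound 4 the estimate is 220 nM, ranging from 110 nM to 450 nM. For compound 4 the expected step is a 1.3-fold higher number from compound 1 to compound 4 (0.13 log units; within the scatter).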

Compound 4, half-maximal inhibitory concentration: 281 nM
The estimate for compound 4 lay 1.3-fold (0.11 log units) below the measured number; low and high end bracket the measured number.
By their numbers in this assay, from the lowest: compounds 1, 2, 4 and 3 (each within the scatter of the next, the first and the last beyond it).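

Among the compounds shown here, compound 1 and compound 4 give the first measured change on this aromatic carbon of the five-membered ring, and in this assay swapping 4-methoxyphenyl for 3-methylphenyl gives a 1.7-fold higher number from compound 1 to compound 4 (0.24 log units; within the scatter). At this position, then, a group without the hydrogen-bond acceptor counted in 4-methoxyphenyl gives a number that cannot be told apart from that of compound 1. No measurement shown offers a reason for this result.

Still open, on these data alone, is how this position responds to a phenyl ring carrying an amine or a carboxylic acid. A longer chain in place of the ring is equally untested here.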